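Swapping the aryl group on the oxadiazoline core of compound 1

The source may report more compounds than this note shows. Statements on the series, on what has been measured and on what is new or still open speak of the compounds shown alone.

Three compounds have been measured so far:
- compound 1, `COc1cc(C2=NN(C(C)=O)C(c3c(Cl)cccc3Cl)O2)cc(OC)c1OC`: 15.9%
- compound 2, `COc1cc(C(=O)N/N=C/c2ccccc2C(F)(F)F)cc(OC)c1OC`: 35.6%
- compound 3, `COc1cc(C(=O)N/N=C/c2ccc(Cl)c(Cl)c2)cc(OC)c1OC`: 32.7%

All three were tested in a functional assay on BGC-823 cells (Homo sapiens) for antiproliferative activity, read by MTT assay, tested at 5 uM; on this read-out lower numbers stand for a weaker effect and higher numbers for a stronger effect at the one concentration tested. On these numbers compound 1 stands lowest, with its nearest neighbour compound 3 beyond the usual scatter and compound 2 further still, so compound 1 is the weakest of the three.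

Compound 4, `COc1cc(C2=NN(C(C)=O)C(c3cccc(C(F)(F)F)c3)O2)cc(OC)c1OC`, keeps the core of compound 1 and changes one group: 3-(trifluoromethyl)phenyl in place of 2,6-dichlorophenyl on a saturated ring carbon. Within the data shown here, no measured pair shows what such a swap does on this core, so only a modest shift is expected, if any, in either direction within or near the scatter. The step of a number 6.1 percentage points higher from compound 1 to compound 4 (within the scatter) is therefore expected to be small, and compound 4 is estimated to give 22%, between 8% and 40%.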

Compound 4, a percentage reported as inhibition, at one concentration (the size of the read-out at that concentration, not a potency): 41.1%
The estimate for compound 4 lay 19.1 percentage points below the measured number; the measured number lies above the stated range.
By their numbers in this assay, from the lowest: compound 1; then compounds 3, 2 and 4 (each within the scatter of the next).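

In this assay, among these compounds, the group on the saturated ring carbon of the shared core clearly matters: 3-(trifluoromethyl)phenyl in place of 2,6-dichlorophenyl gives a number 25.2 percentage points higher from compound 1 to compound 4 (beyond the scatter), the first measured change at this position. Nothing available explains the size of this step.

On these data alone, this single swap alters both the substituent and its place on the phenyl group, so the contribution of each remains open. Also open, as far as these compounds go, is how an amine or a carboxylic acid on that phenyl group would read.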